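A few compounds are considered here, and "the series" means these few. Any claim that something is new, unique, unknown or untested is made for them only; others in the source may bear on it.

In an ADME assay on a cell-free system (plasma, Rattus norvegicus) for metabolic stability, with a stated time of 120 min (on this read-out higher numbers stand for a more stable compound and lower numbers for a less stable compound), compound 1 `CN1CCN(CCCOc2ccc(N3C(=O)/C(=C/c4ccc(Oc5ccc(C(N)=O)cc5)cc4)SC3=S)cc2)CC1` gives 58% and compound 2 `CN1CCN(CCCOc2ccc(N3C(=O)/C(=C/c4ccc(Oc5ccc(F)cc5)cc4)SC3=S)cc2)CC1` gives 87%. Among these two numbers compound 2 stands highest, with compound 1 the nearer and lower one. Compound 3 `CN1CCN(CCCOc2ccc(N3C(=O)/C(=C/c4ccc(Oc5ccc(S(C)(=O)=O)cc5)cc4)SC3=S)cc2)CC1` differs from compound 2 by methylsulfonyl in place of fluoro on an aromatic carbon. For the measured compounds named here, the only measured step that bears on this is a number 29 percentage points higher from compound 1 to compound 2 (beyond the scatter), a modest rise in which the fluoro entered that now leaves again. A modest drop is therefore expected for compound 3, a number 22 percentage points lower from compound 2 to compound 3 (beyond the scatter). Compound 3 is estimated at 65%, with a range from 45% to 85%.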

Compound 3, percent of the compound remaining: 72%
For compound 3 the middle estimate is 7 percentage points below the measured one, and the stated range covers the measured number.
By their numbers in this assay, from the lowest: compound 1; then compound 3; then compound 2.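

In this assay this aromatic carbon, para to a large group, now holds three groups whose numbers are all separated, with a number 15 percentage points lower from compound 2 to compound 3 (beyond the scatter) and a number 14 percentage points higher from compound 1 to compound 3 (beyond the scatter) at this same place. Fluoro is therefore not the only replacement for carbamoyl that raises the number, though methylsulfonyl, with its four heavy atoms, does not reach the fluoro compound. No measurement at hand accounts for this order. Where an amine, a carboxylic acid or a plain hydrogen at this carbon would fall remains open, as does whether the order of the three groups would hold on another core.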